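The source may report more compounds than this note shows. Statements on the series, on what has been measured and on what is new or still open speak of the compounds shown alone.

Among the compounds with values here, compound 3 `COc1ccc(F)cc1CNCCCNc1ccnc2cc(-c3ccc(C(C)(C)C)cc3)ccc12` gives 32000 nM in a physicochemical assay for solubility, with a stated time of 18 h, at pH 7.4 (a lower number here means a less soluble compound, a higher number a more soluble compound), the highest of the three numbers measured so far; compound 1 `COc1cccc(Oc2ccc3c(NCCCNCc4cc(F)ccc4OC)ccnc3c2)c1` comes nearest with 14500 nM, and compound 2 `COc1ccc(F)cc1CNCCCNc1ccnc2cc(CCc3ccccc3)ccc12` lies furthest with 4200 nM. Compound 4 `COc1ccc(F)cc1CNCCCNc1ccnc2cc(Oc3ccc(Cl)cc3)ccc12` differs from compound 3 by 4-chlorophenoxy in place of 4-(tert-butyl)phenyl on an aromatic carbon. The step most in point is a 2.2-fold higher number from compound 1 to compound 3 (0.34 log units; beyond the scatter), since compound 1 carries 3-methoxyphenoxy on that same aromatic carbon; a 7.6-fold higher number from compound 2 to compound 3 (0.88 log units; beyond the scatter) and a 3.5-fold lower number from compound 1 to compound 2 (0.54 log units; beyond the scatter) show how wide the spread across this position has been. Because a 2.2-fold higher number from compound 1 to compound 3 (0.34 log units; beyond the scatter) was modest, returning to an aryloxy group of this kind is expected to lower the number modestly, a 2.7-fold lower number from compound 3 to compound 4 (0.43 log units; beyond the scatter). Compound 4 is therefore estimated at 12000 nM, with a range of 4000 nM to 35000 nM.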

Compound 4, solubility: 14500 nM
Compound 4: middle estimate off by 1.2-fold (0.08 log units), on the low side; measured number inside the range.
By their numbers in this assay, from the lowest: compound 2; then compounds 1 and 4 (each within the scatter of the next); then compound 3.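

In this assay, swapping 3-methoxyphenyl for 4-chlorophenyl on the oxygen changes nothing measurable (no change at the digits printed from compound 1 to compound 4 (within the scatter)), so among the compounds shown this aryl substitution does not move the number, which no earlier pair could show. Replacing either carbon-linked group does move it, in opposite directions (a 2.2-fold lower number from compound 3 to compound 4 (0.34 log units; beyond the scatter); a 3.5-fold higher number from compound 2 to compound 4 (0.54 log units; beyond the scatter)). No evidence is given that explains these steps. Still open, going by these compounds, is how an amine, a carboxylic acid or a longer chain on this aromatic carbon would read in this assay.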